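Chloro substitution on the shared core: a purine series note

The source may report more compounds than this note shows. Statements on the series, on what has been measured and on what is new or still open speak of the compounds shown alone.

Measured so far:
compound 1 `COc1ccc(N(C)c2ncnc3c2ncn3Cc2ccc(OC)c(OC)c2)cc1`: > 100000 nM
compound 2 `COc1ccc(N(C)c2ncnc3c2ncn3Cc2cc(OC)c(OC)c(OC)c2)cc1`: > 100000 nM

In a functional assay on K562 cells (Homo sapiens) for antiproliferative activity, read by MTT assay, with a stated time of 48 h (on this read-out higher numbers stand for weaker inhibition of growth and lower numbers for stronger inhibition of growth), compound 1 gives only a limit, > 100000 nM. Compound 2 likewise gives only a limit in this assay, > 100000 nM. Going by the values given here, the one measured step, a step that the two limits leave unreadable from compound 1 to compound 2, is therefore not readable in size, as the limit of > 100000 nM in this assay, at which 2 of the 2 values shown sit, shows. Compound 3 `COc1ccc(N(C)c2nc(Cl)nc3c2ncn3Cc2ccc(OC)c(OC)c2)cc1` differs from compound 1 by chloro in place of hydrogen on an aromatic carbon. Among the compounds with values here, no measured step bears on this change, so the expected step of a number no higher from compound 1 to compound 3 (the limit leaves the size open) rests on compound 1 alone, and a limit is again the likeliest outcome. Compound 3 is estimated at 100000 nM, with a range from 20000 nM to 500000 nM.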

Compound 3, concentration for 50% growth inhibition: 27000 nM
The estimate for compound 3 lay 3.7-fold (0.57 log units) above the measured number; measured number inside the range.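

Chloro in place of hydrogen on an aromatic carbon, between two ring nitrogen atoms, gives an at least 3.7-fold lower number from compound 1 to compound 3 (0.56 log units; beyond the scatter) in this assay. This position on the shared core therefore responds to substitution, whereas the methoxy change on the benzyl side gave no readable step. Compound 3 alone of the three gives a number rather than a limit: the limit of > 100000 nM in this assay, at which 2 of the 3 values shown sit.

On these data alone, whether another group at this position, such as fluoro or an amine, would serve as well as chloro remains open. Also open, as far as these compounds go, is whether chloro has the same effect with the added methoxy of compound 2.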